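A few compounds are considered here, and "the series" means these few. Any claim that something is new, unique, unknown or untested is made for them only; others in the source may bear on it.

Measured compounds:
Compound 1 `Nc1ccn(C[C@H](O)[C@H]2OC(=O)C(OCc3ccccc3)=C2OCc2ccccc2)c(=O)n1` gives 44300 nM.
Compound 2 `Nc1ccn(CCC2(N)OC(=O)C(OCc3ccccc3)=C2OCc2ccccc2)c(=O)n1` gives only a limit of the assay, > 100000 nM.
Compound 3 `NC1(CCn2c(=O)[nH]c(=O)[nH]c2=O)OC(=O)C(OCc2ccccc2)=C1OCc1ccccc1` also gives only a limit, > 100000 nM.

These numbers come from a functional assay on HepG2 cells (Homo sapiens) for inhibition, read by MTT assay, with a stated time of 72 h; on this read-out higher numbers stand for weaker inhibition and lower numbers for stronger inhibition. Compound 1 is the only one of the three that returns a number in this assay; the values of compound 2 and compound 3 are limits, and the step from compound 2 to compound 3, a step that the two limits leave unreadable from compound 2 to compound 3, cannot be read because both of them sit at the limit of > 100000 nM in this assay, at which 2 of the 3 values shown sit. The change between those two is a group of 9 heavy atoms (3 carbon, 3 nitrogen, 3 oxygen; one six-membered aromatic ring with 3 hetero atoms) in place of a group of 8 heavy atoms (4 carbon, 3 nitrogen, 1 oxygen; one six-membered aromatic ring with 2 hetero atoms), on a saturated chain carbon, two bonds along the chain from a saturated ring carbon. How the core of compound 1 differs from the core of compound 2 is not broken down here.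

Compound 4 `O=C1O[C@H]([C@@H](O)Cn2c(=O)[nH]c(=O)[nH]c2=O)C(OCc2ccccc2)=C1OCc1ccccc1` is not yet measured. It differs from compound 1 by a group of 9 heavy atoms (3 carbon, 3 nitrogen, 3 oxygen; one six-membered aromatic ring with 3 hetero atoms) in place of a group of 8 heavy atoms (4 carbon, 3 nitrogen, 1 oxygen; one six-membered aromatic ring with 2 hetero atoms), on a saturated chain carbon, two bonds along the chain from an oxygen on a saturated carbon and a saturated ring carbon, the same kind of change as from compound 2 to compound 3, though the surroundings differ: in compound 4 the change sits two bonds along the chain from an oxygen on a saturated carbon and a saturated ring carbon, whereas in compound 3 it sits two bonds along the chain from a saturated ring carbon alone. Since the measured step of this kind is unreadable, the step from compound 1 to compound 4 is estimated as a 1.8-fold higher number from compound 1 to compound 4 (0.26 log units; within the scatter), a weakening that rests mainly on compound 1 already standing at 44300 nM. Compound 4 is therefore expected to give 80000 nM, between 30000 nM and 200000 nM, in this assay.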

Compound 4, half-maximal inhibitory concentration: > 100000 nM
Compound 4: no number, only a limit; the forecaster's own chance of this, stated with the estimate: 55%; middle value at least 1.2-fold (0.09 log units) from the limit.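

In this assay, placing the group with a six-membered aromatic ring with 3 hetero atoms where compound 1 carries the group with a six-membered aromatic ring with 2 hetero atoms gives an at least 2.2-fold higher number from compound 1 to compound 4 (0.35 log units; beyond the scatter), so on the core of compound 1 this change weakens inhibition by more than the usual scatter. On these data alone, compound 4 gives > 100000 nM, which is a limit of the assay and not a number, so the printed step is only the smallest size the change could have, and its true size remains unknown. Whether the change acts the same way on the core of compound 2 cannot be said, because neither end of the step from compound 2 to compound 3 gives a number: the limit of > 100000 nM in this assay, at which 3 of the 4 values shown sit.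

Within the data shown here, compound 1 gives 44300 nM, the only number here, so the series offers a single measured starting point for any comparison. As far as these compounds go, it remains open whether a simple amine or a carboxylic acid on the same chain, in place of either aromatic ring group, would give stronger or weaker inhibition.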